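From phenyl to propyl on a sulfur

The source may report more compounds than this note shows. Statements on the series, on what has been measured and on what is new or still open speak of the compounds shown alone.

Compound 1 `Cc1c(C)c2c(c(N(C)C)c1N)CC(C)(C)O2` gives 22.3 mg/kg
Compound 2 `Cc1c(N)c(C)c2c(c1CN1CCCCC1)OC(C)(C)C2` gives > 50 mg/kg (a limit of the assay, not a number)
Compound 3 `Cc1c(C)c2c(c(C)c1N)CC(C)(CSc1ccccc1)O2` gives 24.7 mg/kg

In a functional assay on the whole organism with Mus musculus as the target (a higher number here means that more compound is needed for the effect, a lower number that less compound is needed), compound 3 gives 24.7 mg/kg and compound 1 gives 22.3 mg/kg, two values that lie within the usual scatter of each other. Compound 2 has only a limit, > 50 mg/kg, so it offers no exact number for comparison.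

Compound 4 `CCCSCC1(C)Cc2c(C)c(N)c(C)c(C)c2O1` has not been measured yet. It carries propyl in place of phenyl on a sulfur and keeps the rest of compound 3 unchanged. For the measured compounds named here, no measured pair of compounds shows this change on its own, so the data give no direct guide to its size or direction. Going by the values given here, the expectation therefore starts from compound 3 at 24.7 mg/kg, the only measured compound with this sulfur, and no shift beyond the scatter is expected in this assay. The expected step of a 1.1-fold higher number from compound 3 to compound 4 (0.02 log units; within the scatter) is correspondingly small. For compound 4 the estimate is 26 mg/kg. The expected range runs from 11 mg/kg to 50 mg/kg.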

Compound 4, dose for 50% inhibition: 24.6 mg/kg
Estimate against measurement, compound 4: 1.1-fold (0.02 log units) above; low and high end bracket the measured number.
By their numbers in this assay, from the lowest: compounds 1, 4 and 3 (each within the scatter of the next). At a limit, above all of these: compound 2.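

Going from phenyl to propyl on a sulfur in this assay gives a 1.0-fold lower number from compound 3 to compound 4 (0.00 log units; within the scatter), the only step in this set that compares two compounds differing in one place. At this position, the aromatic ring can therefore give way to an open chain, with 3 heavy atoms in place of 6, and the two values stay within the scatter of each other. Nothing in the data shown explains why these two groups read alike.

Only phenyl and propyl are shown on this sulfur, so it stays open whether an amine, a carboxylic acid or a longer chain there would also stay within the scatter of compound 3. As far as these compounds go, it is also open whether the same swap would read alike on a different core, since compound 1 and compound 2 differ from compound 3 in more than one place.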